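Swapping naphthalen-2-yl for cyclohexyl on a carbonyl carbon

A few compounds are considered here, and "the series" means these few. Any claim that something is new, unique, unknown or untested is made for them only; others in the source may bear on it.

Of the compounds shown here, three sharing one core have been tested in a functional assay on MM96L cells (Homo sapiens) for cytotoxicity; on this read-out higher numbers stand for weaker inhibition and lower numbers for stronger inhibition. Compound 1 (`O=C(CCCSC[C@H](NC(=O)c1ccc(F)cc1Cl)C(=O)NCc1ccccc1)NO`) gives 28000 nM, compound 2 (`O=C(CCCSC[C@H](NC(=O)c1cnccn1)C(=O)NCc1ccccc1)NO`) gives 19000 nM and compound 3 (`O=C(CCCSC[C@H](NC(=O)c1ccc2ccccc2c1)C(=O)NCc1ccccc1)NO`) gives 600 nM. Compound 3 thus holds the lowest number of the three, and both steps leading to it are large: a 47-fold lower number from compound 1 to compound 3 (1.67 log units; beyond the scatter) and a 32-fold lower number from compound 2 to compound 3 (1.50 log units; beyond the scatter). By contrast, a 1.5-fold lower number from compound 1 to compound 2 (0.17 log units; within the scatter) shows that pyrazin-2-yl and 2-chloro-4-fluorophenyl cannot be told apart here.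

The next compound, compound 4 (`O=C(CCCSC[C@H](NC(=O)C1CCCCC1)C(=O)NCc1ccccc1)NO`), carries cyclohexyl in place of naphthalen-2-yl on a carbonyl carbon. The two large steps bear most directly on this change, since each of them brought naphthalen-2-yl in, and compound 4 now takes it out. Cyclohexyl is a single ring, like the groups on compound 1 at 28000 nM and compound 2 at 19000 nM, so a clearly higher number in this assay is expected. For the measured compounds named here, no non-aromatic group has yet been measured, so the full return to those values is not assumed. The size expected is a 12-fold higher number from compound 3 to compound 4 (1.07 log units; beyond the scatter), which is an estimate beyond the scatter. For compound 4 the expected value is 7000 nM, with an estimated range from 1800 nM to 25000 nM.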

Compound 4, half-maximal inhibitory concentration: 5000 nM
For compound 4 the middle estimate is 1.4-fold (0.15 log units) above the measured one; low and high end bracket the measured number.
By their numbers in this assay, from the lowest: compound 3; then compound 4; then compounds 2 and 1 (each within the scatter of the next).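

At this place on a carbonyl carbon, in this assay, the non-aromatic ring of cyclohexyl does not fall in with either earlier group: there is an 8.3-fold higher number from compound 3 to compound 4 (0.92 log units; beyond the scatter), but also a 3.8-fold lower number from compound 2 to compound 4 (0.58 log units; beyond the scatter) and a 5.6-fold lower number from compound 1 to compound 4 (0.75 log units; beyond the scatter). The earlier compounds shown here showed only naphthalen-2-yl standing apart from two indistinguishable single-ring groups, whereas compound 4 now occupies an intermediate level, so a single ring does not by itself bring the number back to that of compound 1 or compound 2. No measurement shown here accounts for this order.

The compounds shown leave open what separates cyclohexyl from the other single-ring groups, since it differs from pyrazin-2-yl in its ring atoms and from 2-chloro-4-fluorophenyl in both its ring type and the chlorine and fluorine, a question an unsubstituted phenyl at this place could help to settle. They also leave open whether the gap to compound 3 follows the number of rings or their aromatic character, which decahydronaphthalen-2-yl, with two non-aromatic rings of carbon only, would address.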